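Swapping a Diethylamino for a Piperidine Ring

The source may report more compounds than this note shows. Statements on the series, on what has been measured and on what is new or still open speak of the compounds shown alone.

Of the compounds shown here, three with the shared core have been tested in a functional assay on A549 cells (Homo sapiens) for antiproliferative activity, read by MTT assay, with a stated time of 48 h; a lower number here means a stronger inhibitor, a higher number a weaker inhibitor. Compound 1 `O=c1cc(-c2ccccc2)oc2cc(OCc3ccccc3)c(OCCCCN3CCCCC3)c(O)c12` gives 1900 nM. Compound 2 `COc1cc2oc(-c3ccccc3)cc(=O)c2c(O)c1OCCCN1CCCCC1` gives 17000 nM, and compound 3 `CCN(CC)CCCCOc1c(OC)cc2oc(-c3ccccc3)cc(=O)c2c1O` gives 35000 nM, the highest of the three numbers, so compound 3 is the weakest inhibitor among them; its nearest neighbour is compound 2, and compound 1 lies furthest from it.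

Compound 4 `COc1cc2oc(-c3ccccc3)cc(=O)c2c(O)c1OCCCCN1CCCCC1` has not yet been measured. It differs from compound 3 in one place: piperidin-1-yl in place of diethylamino on a saturated chain carbon, four bonds along the chain from an oxygen on an aromatic ring. For the measured compounds named here, one measured step bears on this: a 2.1-fold higher number from compound 2 to compound 3 (0.31 log units; beyond the scatter). That step runs in the opposite direction, exchanging the ring amine for the open-chain one on a chain one bond shorter, and it gave a modest rise in the number. Reversing that exchange here is therefore expected to move the number the other way by a similar, modest amount, about a 2.1-fold lower number from compound 3 to compound 4 (0.31 log units; beyond the scatter). Going by the values given here, compound 1, which also carries the four-bond chain ending in the ring amine but has a different group on the core, gives a far lower number, yet no single-change step connects it to compound 4, so it offers only a loose hint. Compound 4 is therefore expected to give about 17000 nM, within a range from 7000 nM to 40000 nM.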

Compound 4, half-maximal inhibitory concentration: 34000 nM
Compound 4: the middle estimate sits 2.0-fold (0.30 log units) below what was measured; measured number inside the range.
By their numbers in this assay, from the lowest: compound 1; then compounds 2, 4 and 3 (each within the scatter of the next, the first and the last beyond it).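

In this assay piperidin-1-yl in place of diethylamino, four bonds along the chain from an oxygen on an aromatic ring, leaves no difference that can be told from scatter, with a 1.0-fold lower number from compound 3 to compound 4 (0.01 log units; within the scatter); the exchange of these two amines on this chain therefore does not repeat the modest separation seen in a 2.1-fold higher number from compound 2 to compound 3 (0.31 log units; beyond the scatter). The step that puts (piperidin-1-yl)methyl in place of piperidin-1-yl also stays within the scatter, at a 2.0-fold higher number from compound 2 to compound 4 (0.30 log units; within the scatter), so these compounds give no clear sign that this extension of the chain matters. The one large step is a change elsewhere, hydrogen in place of phenyl on a saturated chain carbon bound to an oxygen on an aromatic ring, at an 18-fold higher number from compound 1 to compound 4 (1.25 log units; beyond the scatter), which makes that group, not the amine, the change with by far the largest step among these compounds.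

No measurement shown here accounts for any of these steps. Still open, on these data alone, is whether a morpholine or a dimethylamino group at the chain end, or a longer chain, would separate from these amines, and whether the large step from that phenyl group would also appear with diethylamino at the chain end.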